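The compounds below may be only part of what the source reports. "The series", "measured", "known", "first", "only" and "open" are said of these compounds alone.

Measured compounds:
- Compound 1, `CCOC(=O)C1=C(N)Oc2ccccc2C1C(C#N)C(=O)OCC`: 697000 nM
- Compound 2, `CCOC(=O)C1=C(N)Oc2ccc(CC)cc2C1C(C#N)C(=O)OCC`: 121000 nM

Both were tested in an assay on isolated protein for binding affinity to Bcl-2-like protein 2 (Homo sapiens), read by fluorescence polarization; on this read-out lower numbers stand for stronger inhibition and higher numbers for weaker inhibition. Among the measured compounds shown here, of the two numbers, compound 2 holds the lower one; its nearest neighbour is compound 1, and the single step between them is a 5.8-fold lower number from compound 1 to compound 2 (0.76 log units; beyond the scatter), brought about by an ethyl group in place of a hydrogen on an aromatic carbon of the shared core.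

Compound 3, `CCCc1ccc2c(c1)C(C(C#N)C(=O)OCC)C(C(=O)OCC)=C(N)O2`, has not yet been measured in this assay. It differs from compound 2 by methyl in place of hydrogen on a saturated chain carbon, two bonds along the chain from an aromatic carbon; read one bond further out, this is ethyl to propyl.

For the measured compounds named here, the only step that bears on this is the one from compound 1 to compound 2, where adding a carbon chain at this position on the core lowered the number modestly. Lengthening that chain by a further carbon is a smaller change than introducing it, so a smaller step is expected here, most likely towards a lower number, and it may not exceed the scatter.

Compound 3 is therefore expected to give about 80000 nM, within a range from 30000 nM to 250000 nM. The expected step is a 1.5-fold lower number from compound 2 to compound 3 (0.18 log units; within the scatter).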

Compound 3, inhibition constant: 56700 nM
The estimate for compound 3 lay 1.4-fold (0.15 log units) above the measured number, and the stated range covers the measured number.
By their numbers in this assay, from the lowest: compound 3; then compound 2; then compound 1.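

In this assay, lengthening the ethyl group of compound 2 to the propyl group of compound 3 moves the number further in the same direction (a 2.1-fold lower number from compound 2 to compound 3 (0.33 log units; beyond the scatter)), so the gain seen with the ethyl group does not stop at that chain length. Among the compounds shown here, measured against the hydrogen of compound 1, the propyl group gives a step (a 12-fold lower number from compound 1 to compound 3 (1.09 log units; beyond the scatter)) that is clearly larger than the scatter, and compound 3 is the strongest of the three, with no compound here going against the order hydrogen, ethyl, propyl. Nothing available explains why the longer chain gives the lower number.

As far as these compounds go, three points on one line cannot show how far this trend runs, so it remains open whether a butyl group or a longer chain would lower the number further or reverse the trend. A branched chain such as isopropyl, or a chain ending in an amine or a carboxylic acid, would also show whether only length counts at this position, or whether the shape and the end of the chain matter too.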